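Compound 3, a Tertiary Anilino Variant of Compound 2

The source may hold more compounds than are shown below. What is called first, only, known or untested is meant among the compounds shown, and "the series" means these compounds.

Compound 2 `CC(C(=O)NCc1ccc(C(F)(F)F)nc1NCc1ccccc1)c1ccc(NS(C)(=O)=O)c(F)c1` was examined in a functional assay on CHO-K1 cells for antagonist activity at transient receptor potential cation channel subfamily V member 1 (Homo sapiens), read by FLIPR (on this read-out lower numbers stand for stronger inhibition and higher numbers for weaker inhibition), where compound 2 gives 203 nM. Among the compounds with values here, of the two numbers so far this is the higher one; its nearest neighbour is compound 1 `Cc1ccc(Cl)cc1Nc1nc(C(F)(F)F)ccc1CNC(=O)C(C)c1ccc(NS(C)(=O)=O)c(F)c1`, which in this assay gives 140 nM, and the pair sit within the scatter. Within the data shown here, the only step between measured compounds, a 1.5-fold higher number from compound 1 to compound 2 (0.16 log units; within the scatter), exchanged one substituent on that nitrogen and barely moved the number. Compound 3 `CC(C(=O)NCc1ccc(C(F)(F)F)nc1N(C)c1ccccc1)c1ccc(NS(C)(=O)=O)c(F)c1` differs from compound 2 by methyl(phenyl)amino in place of benzylamino on an aromatic carbon. The phenyl now sits directly on the nitrogen, which carries a methyl instead of its hydrogen. Among the measured compounds shown here, no measured step rehearses such a rearrangement, so the expectation rests mainly on the small effect of a 1.5-fold higher number from compound 1 to compound 2 (0.16 log units; within the scatter) and on caution about the lost donor. Compound 3 is therefore expected to give 500 nM (range 150 nM to 2000 nM) in this assay, an estimated step of a 2.5-fold higher number from compound 2 to compound 3 (0.39 log units; beyond the scatter), leaning weaker.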

Compound 3, half-maximal inhibitory concentration: 57.4 nM
Beside the measured number, compound 3's estimate is 8.7-fold (0.94 log units) above it; the measured number lies below the stated range.
By their numbers in this assay, from the lowest: compound 3; then compounds 1 and 2 (each within the scatter of the next).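

In this assay this position, on an aromatic carbon next to the ring nitrogen, proves able to do without the hydrogen-bond donor of the group: methyl(phenyl)amino in place of benzylamino gives a 3.5-fold lower number from compound 2 to compound 3 (0.55 log units; beyond the scatter) and no loss. Set against (5-chloro-2-methylphenyl)amino, the same group gives a 2.4-fold lower number from compound 1 to compound 3 (0.39 log units; beyond the scatter) and so moves the number beyond the scatter, which the earlier 1.5-fold higher number from compound 1 to compound 2 (0.16 log units; within the scatter) did not do. Nothing available explains why the number falls with this change.

The compounds shown do not separate the effect of the methyl on the nitrogen from that of the phenyl sitting directly on it. As far as these compounds go, it also stays open whether an ethyl group on that nitrogen, or a morpholine in place of the whole group, would keep this level of inhibition.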